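The source may report more compounds than this note shows. Statements on the series, on what has been measured and on what is new or still open speak of the compounds shown alone.

Measured compounds:
Compound 1 `O=[N+]([O-])c1ccc(Nc2nccc(-c3ccc(F)cc3)n2)cc1` — 7950 nM
Compound 2 `CC(C)c1ccccc1Nc1nccc(-c2ccc(Br)cc2)n1` — 7030 nM
Compound 3 `Cc1cccc(Nc2nccc(-c3ccc(Cl)cc3Cl)n2)c1` — 13200 nM

These three share a core and differ in the groups on their two outer rings. In a functional assay on HepG2 cells (Homo sapiens) for antiproliferative activity, read by MTT assay (on this read-out higher numbers stand for weaker inhibition and lower numbers for stronger inhibition), compound 3 gives the highest of the three numbers, yet its gaps to compound 1 and to compound 2 both lie within the usual scatter, so the three cannot be told apart on these data.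

Compound 4 `COc1cccc(Nc2nccc(-c3ccc(Cl)cc3Cl)n2)c1` is the next compound. Its change from compound 3 is methoxy in place of methyl on an aromatic carbon. For the measured compounds named here, no measured pair shows what such a swap does here, so the step from compound 3 to compound 4 is expected to stay within the scatter of this assay, with no clear direction: a 1.0-fold lower number from compound 3 to compound 4 (0.01 log units; within the scatter). Compound 4 is accordingly estimated at 13000 nM, within a range from 5000 nM to 35000 nM.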

Compound 4, half-maximal inhibitory concentration: 96900 nM
Beside the measured number, compound 4's estimate is 7.5-fold (0.87 log units) below it; the whole stated range lies below it.
By their numbers in this assay, from the lowest: compounds 2, 1 and 3 (each within the scatter of the next); then compound 4.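

On this aromatic carbon, meta to a large group, methoxy in place of methyl gives a 7.3-fold higher number from compound 3 to compound 4 (0.87 log units; beyond the scatter) in this assay and so weakens inhibition beyond the scatter. For the compounds shown here, this position therefore responds to a small change of group, something the earlier compounds could not show, as they differ in more than one place. No available evidence explains this step.

As far as these compounds go, whether a hydroxyl, an amine or a longer chain such as ethoxy at this place would behave like methyl or like methoxy remains open. From the compounds shown here alone, it is also open whether the same swap would have this effect with the other ring substituents of compound 1 or compound 2.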